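Replacing Cyclopropylamino with Benzyloxy: Expectation Before Measurement

The source may report more compounds than this note shows. Statements on the series, on what has been measured and on what is new or still open speak of the compounds shown alone.

Of the compounds shown here, three have been tested in a functional assay on L02 cells (Homo sapiens) for inhibition, read by Griess assay, with stated times of 1 h and 24 h; on this read-out lower numbers stand for stronger inhibition and higher numbers for weaker inhibition. Compound 1 `CCCc1nn(C)c2c(NCc3ccc(F)cc3)nc(/C=C/c3nc(C)c(C)nc3C)nc12` gave > 1000000 nM, which is a limit of the assay and not a number. Compound 2 `Brc1ccc(Nc2nc(/C=C/c3ccccc3)nc3ccsc23)cc1` gave > 1000000 nM, again a limit. Compound 3 `COc1cc(/C=C/c2nc(NC3CC3)c3sccc3n2)cc(OC)c1OC` gave > 1000000 nM, also a limit. Compound 3 therefore stands nowhere distinct among the numbers shown: all three values sit at the same limit (the limit of > 1000000 nM in this assay, at which 3 of the 3 values shown sit). Compound 4 `COc1cc(/C=C/c2nc(OCc3ccccc3)c3sccc3n2)cc(OC)c1OC` differs from compound 3 in one place: benzyloxy in place of cyclopropylamino on an aromatic carbon. Going by the values given here, no step between measured compounds exists in the data, and the size of this change cannot be read from them. In this assay the expectation is for no step beyond the scatter, with compound 4 estimated at 1000000 nM, ranging from 200000 nM to 5000000 nM. The expected step is a number no higher from compound 3 to compound 4 (the limit leaves the size open).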

Compound 4, half-maximal inhibitory concentration: > 1000000 nM
Compound 4: only a limit was reported (the forecaster's own chance of this, stated with the estimate: 85%); the middle value lies on the limit itself.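

The step from compound 3 to compound 4 cannot be read, because both values are limits: the limit of > 1000000 nM in this assay, at which 4 of the 4 values shown sit.

The compounds shown leave open how strongly any of them inhibits, and whether benzyloxy in place of cyclopropylamino changes inhibition at all.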